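Compound 4: an Aryl Swap at the Ring Nitrogen

The source may hold more compounds than are shown below. What is called first, only, known or untested is meant among the compounds shown, and "the series" means these compounds.

Compound 1 `CCc1ccccc1-n1nncc1CN1C(=O)C2(C(C#N)=C(N)Oc3c(N)cc4nc5ccccc5nc4c32)c2ccccc21` gives 17900 nM in a functional assay on HepG2 cells (Homo sapiens) for antiproliferative activity, read by MTT assay, with a stated time of 48 h; on this read-out higher numbers stand for weaker inhibition and lower numbers for stronger inhibition.
Compound 2 `N#CC1=C(N)Oc2c(N)cc3nc4ccccc4nc3c2C12C(=O)N(Cc1cnnn1-c1cccc(C(F)(F)F)c1)c1ccccc12` gives 15800 nM in this assay.
Compound 3 `COc1ccccc1-n1nncc1CN1C(=O)C2(C(C#N)=C(N)Oc3c(N)cc4nc5ccccc5nc4c32)c2ccccc21` gives > 50000 nM in this assay, a limit rather than a number.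

Compound 3 therefore stands at the weak end of the three, with an at least 2.7-fold higher number from compound 1 to compound 3 (0.44 log units; beyond the scatter) and an at least 3.1-fold higher number from compound 2 to compound 3 (0.50 log units; beyond the scatter), whereas a 1.1-fold lower number from compound 1 to compound 2 (0.05 log units; within the scatter). Compound 4 `CCc1cccc(C)c1-n1nncc1CN1C(=O)C2(C(C#N)=C(N)Oc3c(N)cc4nc5ccccc5nc4c32)c2ccccc21` differs from compound 3 in that (2-ethyl-6-methylphenyl in place of 2-methoxyphenyl on an aromatic nitrogen). This reverses the methoxy-for-ethyl swap seen in an at least 2.7-fold higher number from compound 1 to compound 3 (0.44 log units; beyond the scatter) and adds a methyl, so that step is the one that bears on it. Compound 4 is therefore expected to show an at least 2.7-fold lower number from compound 3 to compound 4 (0.44 log units; beyond the scatter) in this assay, back toward compound 1. Compound 4 is estimated at 18000 nM, with a range from 8000 nM to 45000 nM.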

Compound 4, half-maximal inhibitory concentration: > 50000 nM
Compound 4 gave a limit, no number (the forecaster's own chance of this, stated with the estimate: 15%); middle value at least 2.7-fold (0.44 log units) from the limit.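

At this position on the aromatic nitrogen, a methyl in place of hydrogen on the aryl ring is enough to weaken the result, with an at least 2.7-fold higher number from compound 1 to compound 4 (0.44 log units; beyond the scatter), so the ethyl does not by itself secure the activity of compound 1. The 2-ethyl-6-methylphenyl group also compares poorly with 3-(trifluoromethyl)phenyl, with an at least 3.1-fold higher number from compound 2 to compound 4 (0.50 log units; beyond the scatter), and a weak result here is thus not confined to 2-methoxyphenyl. The step between compound 3 and compound 4 cannot be read because both values are limits: the limit of > 50000 nM in this assay, at which 2 of the 4 values shown sit.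

Going by these compounds, whether an amine on this phenyl ring, or a longer chain in place of the ethyl, would give a measurable value remains open.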